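Dimethyl substitution on the hydroxycyclohexyl amine of compound 1

The source may hold more compounds than are shown below. What is called first, only, known or untested is meant among the compounds shown, and "the series" means these compounds.

Compound 1 `N#Cc1cnc(NCc2cnccc2C(F)(F)F)cc1N[C@H]1CC[C@@H](O)CC1` gives 4500 nM in an assay on isolated protein for inhibition of protein kinase C delta type (Homo sapiens), read by TR-FRET, with a stated time of 2 h (on this read-out lower numbers stand for stronger inhibition and higher numbers for weaker inhibition), and holds the lowest of the two numbers measured; its nearest neighbour is compound 2 `N#Cc1cnc(NCc2cnccc2C(F)(F)F)cc1N[C@H]1CC[C@@H](n2cncn2)CC1`, at 5500 nM, and the step of a 1.2-fold higher number from compound 1 to compound 2 (0.09 log units; within the scatter) stays within the scatter. Compound 3 `CC1(C)C[C@@H](Nc2cc(NCc3cnccc3C(F)(F)F)ncc2C#N)CC[C@H]1O` carries a change at the same saturated ring: 4-hydroxy-3,3-dimethylcyclohexyl in place of 4-hydroxycyclohexyl on a nitrogen on an aromatic ring. Among the compounds with values here, the only measured step concerns the hydroxy group itself and does not bear on this change, so nothing beyond the scatter is expected in this assay. Compound 3 is estimated at 4500 nM, between 1500 nM and 14000 nM. The expected step is no change at the digits printed from compound 1 to compound 3 (within the scatter).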

Compound 3, half-maximal inhibitory concentration: 2400 nM
Beside the measured number, compound 3's estimate is 1.9-fold (0.27 log units) above it; the measured number falls inside the stated range.
By their numbers in this assay, from the lowest: compounds 3, 1 and 2 (each within the scatter of the next, the first and the last beyond it).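

Within the data shown here, the only earlier step replaced the hydroxy group; this one keeps the hydroxy group and adds to the saturated ring itself. In this assay, 4-hydroxy-3,3-dimethylcyclohexyl in place of 4-hydroxycyclohexyl gives a 1.9-fold lower number from compound 1 to compound 3 (0.27 log units; within the scatter), so this addition to the ring does not move the number beyond the scatter. Nothing on hand gives a reason for this result.

Still open, on these data alone, is whether a single methyl group or two ethyl groups on the same ring would give a step beyond the scatter. The compounds shown also leave open how an amine or a carboxylic acid in place of the hydroxy group would read on the dimethyl ring.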